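The source may report more compounds than this note shows. Statements on the series, on what has been measured and on what is new or still open speak of the compounds shown alone.

Measured compounds:
- compound 1 `CN(C)CCn1cnnc1-c1cc(Oc2ccc(NC(=O)N/N=C/c3cccc(O)c3)cc2F)ccn1`: in a functional assay on A549 cells (Homo sapiens) for cytotoxicity, read by MTT assay, with a stated time of 72 h (on this read-out higher numbers stand for weaker inhibition and lower numbers for stronger inhibition), compound 1 gives > 100000 nM, which is a limit of the assay and not a number.
- compound 2 `CN(C)CCn1cnnc1-c1cc(Oc2ccc(NC(=O)N/N=C/c3ccc(Cl)cc3)cc2F)ccn1`: compound 2 gives 780 nM.
- compound 3 `CN(C)CCn1cnnc1-c1cc(Oc2ccc(NC(=O)N/N=C/c3ccc(F)cc3F)cc2F)ccn1`: compound 3 gives 1870 nM.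

Compound 3 has the highest number of the two that are numbers, above compound 2 by a 2.4-fold higher number from compound 2 to compound 3 (0.38 log units; beyond the scatter). Compound 4 `COc1cc(/C=N/NC(=O)Nc2ccc(Oc3ccnc(-c4nncn4CCN(C)C)c3)c(F)c2)ccc1O` differs from compound 3 by 4-hydroxy-3-methoxyphenyl in place of 2,4-difluorophenyl on a carbon with a double bond to nitrogen. The steps that bear on this change are an at least 120-fold lower number from compound 1 to compound 2 (2.10 log units; beyond the scatter) and an at least 53-fold lower number from compound 1 to compound 3 (1.72 log units; beyond the scatter): removing the hydroxyl-bearing ring cut the number sharply, as shown by the limit of > 100000 nM in this assay, at which 1 of the 3 values shown sits. Putting a hydroxyl-bearing ring back is therefore expected to raise the number strongly, by about a 32-fold higher number from compound 3 to compound 4 (1.51 log units; beyond the scatter). Compound 4 is estimated at 60000 nM, between 10000 nM and 200000 nM.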

Compound 4, half-maximal inhibitory concentration: > 100000 nM
Compound 4 was reported as a limit (the forecaster's own chance of this, stated with the estimate: 55%); middle value at least 1.6-fold (0.22 log units) from the limit.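

Compound 4 shows that compound 1 was not a lone case: a second ring carrying a hydroxyl, here 4-hydroxy-3-methoxyphenyl, also ends at a limit of the assay, not at a number: the limit of > 100000 nM in this assay, at which 2 of the 4 values shown sit.

Against the two halogen-bearing rings the change is large: an at least 53-fold higher number from compound 3 to compound 4 (1.72 log units; beyond the scatter) and an at least 120-fold higher number from compound 2 to compound 4 (2.10 log units; beyond the scatter). The step between compound 1 and compound 4 cannot be read, so these two hydroxyl-bearing rings cannot be ranked.

Still open, from the compounds shown here alone, is whether the hydroxyl itself drives this loss. A 4-methoxyphenyl ring, or a phenyl ring bearing an amine in place of the hydroxyl, would test that.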